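A few compounds are considered here, and "the series" means these few. Any claim that something is new, unique, unknown or untested is made for them only; others in the source may bear on it.

Working notes on the series. Compound 2 `COc1cc(O)cc(CN[C@@H]2CO[C@H](C(c3ccccc3)c3ccccc3)C[C@H]2O)c1` gives 44.2 nM in an assay on Cerebral cortex for inhibition of Norepinephrine transporter (Rattus norvegicus) (on this read-out higher numbers stand for weaker inhibition and lower numbers for stronger inhibition), the highest of the three numbers in hand; compound 1 `COc1ccc(CN[C@@H]2CO[C@H](C(c3ccccc3)c3ccccc3)C[C@H]2O)cc1O` gives 30.2 nM and compound 3 `Oc1ccc(CN[C@@H]2CO[C@H](C(c3ccc(F)cc3)c3ccc(F)cc3)C[C@H]2O)cc1F` gives 7.37 nM. Going by the values given here, the one measured step at this position, a 1.5-fold higher number from compound 1 to compound 2 (0.17 log units; within the scatter), changes only the hydroxy and methoxy pattern. Compound 4 `O[C@@H]1C[C@@H](C(c2ccccc2)c2ccccc2)OC[C@H]1NCc1ccc2occc2c1` differs from compound 2 by 1-benzofuran-5-yl in place of 3-hydroxy-5-methoxyphenyl on a saturated chain carbon bound to an amine nitrogen. Among the compounds with values here, no measured step exchanges the whole ring system here, so nothing in hand bears directly on it; the step from compound 1 to compound 2 shows the position tolerates rearrangement within the scatter. A step no larger than the scatter is therefore expected, a 1.1-fold lower number from compound 2 to compound 4 (0.04 log units; within the scatter). Compound 4 is estimated at 40 nM, between 15 nM and 120 nM.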

Compound 4, inhibition constant: 33.6 nM
Estimate against measurement, compound 4: 1.2-fold (0.08 log units) above; the measured number falls inside the stated range.
By their numbers in this assay, from the lowest: compound 3; then compounds 1, 4 and 2 (each within the scatter of the next).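

In this assay the exchange for 1-benzofuran-5-yl gives a 1.3-fold lower number from compound 2 to compound 4 (0.12 log units; within the scatter) and a 1.1-fold higher number from compound 1 to compound 4 (0.05 log units; within the scatter) and so stands level with both phenyl groups. The earlier compounds shown here only rearranged the hydroxy and methoxy groups, whereas here both groups leave together with no shift beyond the scatter. No evidence in hand accounts for this result.

Open, from the compounds shown here alone, is whether an amine or a carboxylic acid on the ring at this position would also stay within the scatter. Going by these compounds, a longer chain between the ring and the amine nitrogen remains equally open.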